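The source may hold more compounds than are shown below. What is called first, only, known or untested is meant among the compounds shown, and "the series" means these compounds.

Measured so far in a functional assay on MDA-MB-231 cells (Homo sapiens) for antiproliferative activity, read by CCK-8 assay, with a stated time of 72 h; on this read-out higher numbers stand for weaker inhibition and lower numbers for stronger inhibition:
compound 1 `CC1=NN(c2ccc(Br)cc2)C(=O)C12C=CC(=O)C=C2c1cccc(C)c1` gives 2890 nM
compound 2 `CC1=NN(c2ccc(Br)cc2)C(=O)C12C=CC(=O)C=C2c1ccc(C)cc1` gives 15900 nM

Compound 2 stands at the higher of the two numbers, that is, it is the weaker inhibitor of the pair. Among the compounds with values here, the only step between measured compounds, a 5.5-fold higher number from compound 1 to compound 2 (0.74 log units; beyond the scatter), moved the methyl from one position on the attached phenyl ring to another and weakened inhibition by a modest amount.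

Compound 3 `CC1=NN(c2ccc(Br)cc2)C(=O)C12C=CC(=O)C=C2c1ccccc1` is the unmeasured compound. Its change from compound 2 is hydrogen in place of methyl on an aromatic carbon. No measured step removes a methyl outright; the single step shown only shifts one, so it bears on this change only loosely. Since the shifted methyl in compound 2 gave the weaker number, removing it is expected to bring the value back down somewhat, a 2.3-fold lower number from compound 2 to compound 3 (0.36 log units; beyond the scatter), though with wide uncertainty. Compound 3 is therefore expected to give about 7000 nM, between 2500 nM and 25000 nM.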

Compound 3, half-maximal inhibitory concentration: > 100000 nM
Compound 3: no number, only a limit; the forecaster's own chance of this, stated with the estimate: 5%; middle value at least 14-fold (1.15 log units) away from the limit.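

In this assay compound 3 gives > 100000 nM, which is a limit of the assay and not a number. Within the data shown here, the earlier pair showed only that moving the methyl changes inhibition, whereas these results show that the ring without any methyl is weaker than either methyl-bearing compound: an at least 6.2-fold higher number from compound 2 to compound 3 (0.79 log units; beyond the scatter) and an at least 34-fold higher number from compound 1 to compound 3 (1.53 log units; beyond the scatter). Both steps rest on one reading, so each gives only a minimum size for the loss of the methyl: the limit of > 100000 nM in this assay, at which 1 of the 3 values shown sits.

The compounds shown leave open whether the methyl is special or whether another group on this phenyl ring, such as a chlorine, a methoxy or an amine, would restore inhibition equally well. They also leave open whether a longer chain, such as ethyl, would do better or worse than methyl.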